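This account rests on a few compounds, and the source may have more. Where it says the series, first, only, none or still open, it means among the compounds named here.

Measured so far in a toxicity assay on HEK-293T cells (Homo sapiens) for cytotoxicity, read by MTT assay, with a stated time of 72 h; a higher number here means a weaker inhibitor, a lower number a stronger inhibitor:
compound 1 `CN1CCN(CCCCCCn2c3c(c4ccccc42)C(=O)c2c[n+]([O-])c4ccccc4c2C3=O)CC1` gives 5800 nM
compound 2 `CC1(C)O[C@@H](CO)[C@H](Cn2cc(Cn3c4c(c5ccccc53)C(=O)c3c[n+]([O-])c5ccccc5c3C4=O)nn2)O1` gives 120 nM
compound 3 `CC1(C)OCC(Cn2cc(Cn3c4c(c5ccccc53)C(=O)c3c[n+]([O-])c5ccccc5c3C4=O)nn2)O1` gives 5510 nM

Compound 1 holds the highest number of the three; compound 1 and compound 3 sit within the scatter of each other, while compound 2 lies far lower.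

Compound 4 `O=C1c2c[n+]([O-])c3ccccc3c2C(=O)c2c1c1ccccc1n2Cc1cn(CC(O)CO)nn1` arises from compound 1 by 1-(2,3-dihydroxypropyl)-1H-1,2,3-triazol-4-yl in place of 5-(4-methylpiperazin-1-yl)pentyl on a saturated chain carbon bound to an aromatic nitrogen. Among the measured compounds shown here, no measured step makes this same change. For the measured compounds named here, the one measured step, a 46-fold higher number from compound 2 to compound 3 (1.66 log units; beyond the scatter), took away the hydroxymethyl from a side chain and moved the number strongly upward; compound 4 carries two hydroxyl groups on its side chain, compound 1 none. On that basis compound 4 is expected to give a lower number than compound 1, an estimated step of a 15-fold lower number from compound 1 to compound 4 (1.16 log units; beyond the scatter). Compound 4 is estimated at 400 nM, with a range of 80 nM to 2500 nM.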

Compound 4, half-maximal inhibitory concentration: 760 nM
For compound 4 the middle estimate is 1.9-fold (0.28 log units) below the measured one, and the stated range covers the measured number.
By their numbers in this assay, from the lowest: compound 2; then compound 4; then compounds 3 and 1 (each within the scatter of the next).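

In this assay, 1-(2,3-dihydroxypropyl)-1H-1,2,3-triazol-4-yl in place of 5-(4-methylpiperazin-1-yl)pentyl gives a 7.6-fold lower number from compound 1 to compound 4 (0.88 log units; beyond the scatter). 1,2-Dihydroxyethyl gives a 7.3-fold lower number from compound 3 to compound 4 (0.86 log units; beyond the scatter) yet a 6.3-fold higher number from compound 2 to compound 4 (0.80 log units; beyond the scatter), so the hydroxyl-bearing side chains do not sit at one level, and compound 2 stays the lowest of the series. Nothing available explains these steps.

From the compounds shown here alone, whether an amine or a carboxylic acid on the same triazole side chain would land nearer compound 4 or compound 2 remains open. Going by these compounds, the separate shares of the triazole and the hydroxyl groups in the step from the methylpiperazine chain also remain open.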